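This account rests on a few compounds, and the source may have more. Where it says the series, first, only, none or still open, it means among the compounds named here.

Compound 2 `CC(=O)N1CCC(n2c(-c3ccc(OCc4c(-c5c(Cl)cccc5Cl)noc4C(C)C)cc3)nc3ccc(C(=O)O)cc32)CC1` gives 1430 nM in an assay on Huh-7 cells for agonist activity at Bile acid receptor (Homo sapiens), read by a luciferase reporter (on this read-out higher numbers stand for an effect only at larger amounts of compound and lower numbers for an effect already at smaller amounts), and so stands at the highest of the two numbers recorded; its nearest neighbour is compound 1 `CCn1c(-c2ccc(OCc3c(-c4c(Cl)cccc4Cl)noc3C(C)C)cc2)nc2ccc(C(=O)O)cc21`, which in this assay gives 2.31 nM. Within the data shown here, the only measured step at this position, a 620-fold higher number from compound 1 to compound 2 (2.79 log units; beyond the scatter), is large. Compound 3 `CC(C)c1onc(-c2c(Cl)cccc2Cl)c1COc1ccc(-c2nc3ccc(C(=O)O)cc3n2C2CCCCC2)cc1` carries the change (cyclohexyl in place of 1-acetylpiperidin-4-yl on an aromatic nitrogen); the group that enters keeps a six-membered non-aromatic ring but is made of carbon only and carries no hydrogen-bond acceptor, so it lies between the ethyl of compound 1 and the 1-acetylpiperidin-4-yl of compound 2 in what it contains. Among the measured compounds shown here, no measured step has the same pair of groups, so the direction is read by analogy from compound 1 and compound 2 alone. In this assay compound 3 is therefore expected to give a lower number than compound 2, with the step of a 24-fold lower number from compound 2 to compound 3 (1.38 log units; beyond the scatter) judged well short of a full return to compound 1. The estimate for compound 3 in this assay is 60 nM, in a range from 6 nM to 600 nM.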

Compound 3, half-maximal effective concentration: 4.21 nM
Estimate against measurement, compound 3: 14-fold (1.15 log units) above; the whole stated range lies above it.
By their numbers in this assay, from the lowest: compounds 1 and 3 (each within the scatter of the next); then compound 2.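

In this assay, cyclohexyl in place of 1-acetylpiperidin-4-yl brings a 340-fold lower number from compound 2 to compound 3 (2.53 log units; beyond the scatter), so a six-membered non-aromatic ring on this aromatic nitrogen does not by itself go with the high number of compound 2. The other step, a 1.8-fold higher number from compound 1 to compound 3 (0.26 log units; within the scatter), lies within the scatter, so ethyl and cyclohexyl cannot be told apart here, and among these three compounds the large rise is seen only with the 1-acetylpiperidin-4-yl group, whose ring nitrogen and acetyl are the parts that cyclohexyl lacks. No experimental evidence is available to explain this result.

From the compounds shown here alone, it remains open whether the ring nitrogen or the acetyl goes with the high number. A piperidin-4-yl group with a free amine, or a tetrahydropyran-4-yl group with a ring oxygen, would bear on that question.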